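A few compounds are considered here, and "the series" means these few. Any claim that something is new, unique, unknown or untested is made for them only; others in the source may bear on it.

Working notes on the series, antiproliferative screen.

Three compounds carry a number in a functional assay on BGC-823 cells (Homo sapiens) for antiproliferative activity, read by MTT assay, tested at 1 uM (a higher number here means a stronger effect of the compound at the concentration tested, a lower number a weaker effect), so far. Compound 1 `COc1cc(C2=NN(C(C)=O)C(c3c(Cl)cccc3Cl)O2)cc(OC)c1OC` gives -1.4% in this assay, which is the lowest of the three. Compound 2 `COc1cc(C(=O)N/N=C/c2ccccc2C(F)(F)F)cc(OC)c1OC` gives 22.1% in this assay, and compound 3 `COc1cc(C(=O)N/N=C/c2cccc(C(F)(F)F)c2)cc(OC)c1OC` gives 17.7% in this assay. Both open-chain compounds sit beyond the scatter above compound 1: compound 3 is the nearer one, compound 2 the further one. The two open-chain compounds are within the scatter of each other, so no order is drawn between them. For the measured compounds named here, no pair among the three differs in one place, so no single-change step is on record.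

Compound 4 `COc1cc(C2=NN(C(C)=O)C(c3ccccc3C(F)(F)F)O2)cc(OC)c1OC` is the next entry. Against compound 1 the change is 2-(trifluoromethyl)phenyl in place of 2,6-dichlorophenyl on a saturated ring carbon. The shared core of compound 1 and compound 4 is otherwise untouched.

Going by the values given here, with no single-change step to lean on, the expectation rests on compound 1 at -1.4% and on the two open-chain compounds bearing a trifluoromethyl group, compound 2 at 22.1% and compound 3 at 17.7%. The step from compound 1 to compound 4 is expected to be a number 9.4 percentage points higher from compound 1 to compound 4 (within the scatter), a small rise that may not clear the scatter. Compound 4 is expected at 8% in this assay, within -8% to 25%.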

Compound 4, a percentage reported as inhibition, at one concentration (the size of the read-out at that concentration, not a potency): 31.8%
Estimate against measurement, compound 4: 23.8 percentage points below, outside the stated range (above it).
By their numbers in this assay, from the lowest: compound 1; then compounds 3, 2 and 4 (each within the scatter of the next, the first and the last beyond it).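

For the compounds shown here, the step of a number 33.2 percentage points higher from compound 1 to compound 4 (beyond the scatter) is the first single-change comparison, and it shows that in this assay the read-out responds strongly to the aryl group on this saturated ring carbon, with the rest of the shared core held constant. The change replaces 2,6-dichlorophenyl with 2-(trifluoromethyl)phenyl, so the two chlorine atoms leave and the trifluoromethyl group enters in a single step, and this one comparison cannot separate those two parts of the change. Nothing on hand bears on why the number moves this far at this position.

Still open, on these data alone, is how the step divides between the departing and the entering atoms, a question that phenyl without substituents or 2-chlorophenyl at the same carbon would address, as well as whether an amine or a carboxylic acid on that aryl ring would be tolerated. Also open, as far as these compounds go, is whether a longer acyl chain such as propanoyl in place of the acetyl group would shift the number, and since the read-out comes from one concentration, the step says nothing about potency.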